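The compounds below may be only part of what the source reports. "The series", "measured", "known", "first", "only" and "open" are said of these compounds alone.

Measured so far in an ADME assay on microsomes from liver (Rattus norvegicus) for metabolic stability, with a stated time of 10 min; on this read-out higher numbers stand for a more stable compound and lower numbers for a less stable compound:
compound 1 `COc1ccc(Nc2nc(Cl)cn([C@H](C)C3CC3)c2=O)c(C)n1`: 89%
compound 2 `COc1ccc(Nc2nc(Cl)cn([C@H](C)C3CC3)c2=O)c(OC)n1`: 43%
compound 3 `COc1cc(C)c(Nc2nc(Cl)cn([C@H](C)C3CC3)c2=O)c(C)n1`: 79%

Compound 3 gives 79%, compound 1 gives 89% and compound 2 gives 43%. The number of compound 3 lies within the scatter of the number of compound 1 and beyond the scatter of the number of compound 2. Next comes compound 4 `Cc1cc(C)c(Nc2nc(Cl)cn([C@H](C)C3CC3)c2=O)c(C)n1`: methyl in place of methoxy on an aromatic carbon, next to the ring nitrogen.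

Among the compounds with values here, two measured steps bear on this. The large step of a number 46 percentage points lower from compound 1 to compound 2 (beyond the scatter) came with methoxy in place of methyl, the reverse exchange, and at a different aromatic carbon, so its size does not carry over and its direction only hints at a rise. The step of a number 10 percentage points lower from compound 1 to compound 3 (within the scatter) came with methyl in place of hydrogen and shows that compound 3 keeps the number of its parent. Both compound 1 and compound 3 already carry the methoxy that leaves here and sit high in this assay, so no change beyond the scatter is expected. The expected step is a number 5 percentage points higher from compound 3 to compound 4 (within the scatter). Compound 4 is expected at 84%, with an estimated range of 68% to 97%.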

Compound 4, percent of the compound remaining: 87%
Beside the measured number, compound 4's estimate is 3 percentage points below it, within the range that was stated.
By their numbers in this assay, from the lowest: compound 2; then compounds 3, 4 and 1 (each within the scatter of the next).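

In this assay, methyl in place of methoxy on the aromatic carbon next to the ring nitrogen gives a number 8 percentage points higher from compound 3 to compound 4 (within the scatter). The methoxy at this position is therefore not needed to keep the number high, a point compounds 1 and 3 could not show, as both carry it. The exchange between methoxy and methyl also proves not to have one fixed size across the series: the same change on two cores in this assay, a number 46 percentage points lower (beyond the scatter) from compound 1 to compound 2 and a number 8 percentage points lower (within the scatter) from compound 4 to compound 3, 38 percentage points apart, beyond the scatter of two such steps

The compounds shown do not tell whether a larger or more polar group at this carbon, such as an ethyl chain or an amine, would keep the number as methyl does. Within the data shown here, they also leave open what sets the size of the exchange on each core, since only two such pairs are available.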